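Dichlorobenzyl in Place of Fluorophenylsulfonyl on an Inactive Series

The source may hold more compounds than are shown below. What is called first, only, known or untested is meant among the compounds shown, and "the series" means these compounds.

In a functional assay on K562 cells (Homo sapiens) for antiproliferative activity, read by MTT assay and trypan blue exclusion, with a stated time of 72 h (a higher number here means a weaker inhibitor, a lower number a stronger inhibitor), compound 3 `COC(=O)c1ccc(C2SCC(=O)N2c2ccc(N3CCN(S(=O)(=O)c4ccc(F)cc4)CC3)cn2)c(OC)c1` reaches only the assay limit of > 100000 nM, a limit rather than a measured number. Compound 1 `COC(=O)c1ccc(C2SCC(=O)N2c2ccc(N3CCN(Cc4cc(OC)c(OC)c(OC)c4)CC3)cn2)c(OC)c1` also stands at the limit, giving > 100000 nM. Compound 2 `COC(=O)c1ccc(C2SCC(=O)N2c2ccc(N3CCN(Cc4cccc(C)c4)CC3)cn2)c(OC)c1` likewise gives > 100000 nM, again a limit. Because (the limit of > 100000 nM in this assay, at which 3 of the 3 values shown sit), the steps a step that the two limits leave unreadable from compound 1 to compound 2 and a step that the two limits leave unreadable from compound 2 to compound 3 cannot be read in size or direction. Compound 4 `COC(=O)c1ccc(C2SCC(=O)N2c2ccc(N3CCN(Cc4ccc(Cl)c(Cl)c4)CC3)cn2)c(OC)c1` differs from compound 3 by 3,4-dichlorobenzyl in place of (4-fluorophenyl)sulfonyl on an amine nitrogen in a ring. Going by the values given here, no measured step bears on this change, and the three limits give no scale for expecting any size of step in this assay. Compound 4 is therefore expected to stay at the limit, with an estimated 200000 nM and a range from 50000 nM to 1000000 nM. The step that the limit leaves unreadable from compound 3 to compound 4 is expected to be unreadable as well.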

Compound 4, half-maximal inhibitory concentration: > 100000 nM
Compound 4 ended at the assay's limit; the forecaster's own chance of this, stated with the estimate: 85%; the middle value lies beyond the limit too.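

Going by these compounds alone, no step from compound 1, compound 2 or compound 3 to compound 4 can be read, since all four stand at one limit: the limit of > 100000 nM in this assay, at which 4 of the 4 values shown sit. Left open is which group on the amine nitrogen in the ring, if any, would give a measured number in this assay rather than a limit.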